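Benzylamino for diethylamino on the shared core

The source may report more compounds than this note shows. Statements on the series, on what has been measured and on what is new or still open speak of the compounds shown alone.

In a functional assay on G-361 cells (Homo sapiens) for cytotoxicity, read by sulforhodamine B assay (a lower number here means that less compound is tolerated, a higher number that more compound is tolerated), compound 1 (`CCCCNc1nc(C)nc2c1cnn2-c1ccccc1`) gives > 100000 nM, a limit of the assay. In this assay compound 2 (`CCN(CC)c1nc(C)nc2c1cnn2-c1ccccc1`) gives > 100000 nM, also a limit. The step that the two limits leave unreadable from compound 1 to compound 2 is therefore unreadable, and compound 2 stands at the limit of > 100000 nM in this assay, at which 2 of the 2 values shown sit, with no number of its own.

Compound 3 (`Cc1nc(NCc2ccccc2)c2cnn(-c3ccccc3)c2n1`) differs from compound 2 by benzylamino in place of diethylamino on an aromatic carbon. Among the compounds with values here, the only measured step on this core, from butylamino to diethylamino, bears on the amine at the same place, but its size is hidden by the two limits, so no direction or size can be carried over. What both measured compounds show is tolerance up to the limit. Compound 3 is therefore expected to sit at the limit again, 100000 nM with a range of 50000 nM to 200000 nM. The step from compound 2 to compound 3 is estimated as a number no higher from compound 2 to compound 3 (the limit leaves the size open), nothing beyond the scatter.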

Compound 3, concentration lethal to 50% of the cells: > 100000 nM
Compound 3: a limit, no number; the forecaster's own chance of this, stated with the estimate: 80%; the middle value lies on the limit itself.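

No step can be read among compound 1, compound 2 and compound 3, as all three give only a limit and no number: the limit of > 100000 nM in this assay, at which 3 of the 3 values shown sit.

The compounds shown leave open whether butylamino, diethylamino and benzylamino differ at all, and whether any amine on the shared core gives a readable value.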